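This account rests on a few compounds, and the source may have more. Where it says the series, first, only, none or still open, it means among the compounds named here.

- Compound 1 `COc1cc(-c2ccnc3cc(-c4ccc(C(C)=O)cc4)nn23)cc(OC)c1OC`: 3930 nM
- Compound 2 `COc1cc(-c2ccnc3cc(-c4ccc5ccn(C)c5c4)nn23)cc(OC)c1OC`: 657 nM

In a functional assay on B16-F0 cells (Mus musculus) for inhibition, read by CCK-8 assay, with a stated time of 48 h (on this read-out lower numbers stand for stronger inhibition and higher numbers for weaker inhibition), compound 2 gives 657 nM, the lower of the two numbers. Going by the values given here, the only measured step, a 6.0-fold lower number from compound 1 to compound 2 (0.78 log units; beyond the scatter), put 1-methyl-1H-indol-6-yl in place of 4-acetylphenyl. Compound 3 `COc1cc(-c2ccnc3cc(-c4ccc5cnn(C)c5c4)nn23)cc(OC)c1OC` keeps the shared core and changes that group again: 1-methyl-1H-indazol-6-yl in place of 1-methyl-1H-indol-6-yl on an aromatic carbon. Among the compounds with values here, no measured step tests this swap directly, so a 6.0-fold lower number from compound 1 to compound 2 (0.78 log units; beyond the scatter) serves only as a loose guide to size. A small rise within the scatter is expected, a 1.2-fold higher number from compound 2 to compound 3 (0.09 log units; within the scatter). Compound 3 is estimated at 800 nM, with an expected range of 250 nM to 2500 nM.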

Compound 3, half-maximal inhibitory concentration: 1000 nM
Compound 3: middle estimate off by 1.3-fold (0.10 log units), on the low side; the range from low to high includes it.
By their numbers in this assay, from the lowest: compounds 2 and 3 (each within the scatter of the next); then compound 1.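

In this assay the step of a 1.5-fold higher number from compound 2 to compound 3 (0.18 log units; within the scatter) brings a second nitrogen into the five-membered aromatic ring, and at this position the two fused groups cannot be told apart. The step of a 3.9-fold lower number from compound 1 to compound 3 (0.59 log units; beyond the scatter) shows that 1-methyl-1H-indazol-6-yl, like 1-methyl-1H-indol-6-yl, gives a lower number than 4-acetylphenyl. Nothing measured here explains these differences. Still open, on these data alone, is how a group without the methyl, such as 1H-indol-6-yl, would behave here, and how a simple amine or a carboxylic acid on the same aromatic carbon would compare.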